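Triazole aryl swap: compound 3 to compound 4

This account rests on a few compounds, and the source may have more. Where it says the series, first, only, none or still open, it means among the compounds named here.

Measured so far in a functional assay on A549 cells (Homo sapiens) for antiproliferative activity, read by MTT assay; a lower number here means a stronger inhibitor, a higher number a weaker inhibitor:
- compound 1 `CC(=O)c1ccc(-n2cc(COc3ccc(/C=C/C(=O)c4cc5c(cc4O)OC(C)(C)CC5)cc3)nn2)cc1`: 66300 nM
- compound 2 `CC1(C)CCc2c(ccc(C(=O)/C=C/c3ccc(OCc4cn(-c5ccc(Cl)cc5)nn4)cc3)c2O)O1`: "not active" (no number reported)
- compound 3 `COc1ccc(-n2cc(COc3ccc(/C=C/C(=O)c4ccc5c(c4O)CCC(C)(C)O5)cc3)nn2)c([N+](=O)[O-])c1`: "not active" (no number reported)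

Compound 3 has no single number to its name, and compound 2 is the only other entry of this kind. Going by the values given here, the sole numerical reading in this assay belongs to compound 1, at 66300 nM. The next structure is compound 4 `CCc1ccccc1-n1cc(COc2ccc(/C=C/C(=O)c3ccc4c(c3O)CCC(C)(C)O4)cc2)nn1`, which keeps the core of compound 3. The change is 2-ethylphenyl in place of 4-methoxy-2-nitrophenyl on an aromatic nitrogen.

Among the compounds with values here, no measured step between compounds is available to size this change. Compound 2 and compound 3 share the core of compound 4, and neither gave a number, so a large gain is not expected. The likeliest outcome is another entry without a number. If a number is reported, it is expected to fall near the reading for compound 1, at 66300 nM. For compound 4 the estimated value is 70000 nM, with an expected range of 30000 nM to 150000 nM.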

Compound 4, half-maximal inhibitory concentration: 112000 nM
Estimate against measurement, compound 4: 1.6-fold (0.20 log units) below; low and high end bracket the measured number.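

No step can be read from compound 3 to compound 4 in this assay, since compound 3 has no number. The compounds shown leave open how far 2-ethylphenyl in place of 4-methoxy-2-nitrophenyl shifts activity on the shared core. No evidence bears on this result.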